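The compounds below may be only part of what the source reports. "The series", "measured", "known", "first", "only" and "open" are said of these compounds alone.

In a functional assay on A549 cells (Homo sapiens) for antiproliferative activity, read by MTT assay, with a stated time of 72 h (a higher number here means a weaker inhibitor, a lower number a stronger inhibitor), compound 3 (`O=C(CCCCCCc1nc(-c2ccccc2)no1)C(F)(F)F`) gives 7680 nM and sits within the scatter of compound 1 (`Cc1ccc(-c2noc(CCCCCCC(=O)NO)n2)cc1`) at 5810 nM on the same read-out. Compound 2 (`Nc1ccccc1NC(=O)CCCCCCc1nc(-c2ccccc2)no1`) gives 23900 nM and stands apart from compound 3. Going by the values given here, the only measured step, a 3.1-fold lower number from compound 2 to compound 3 (0.49 log units; beyond the scatter) (modest), changes the group on the carbonyl carbon and leaves the aromatic ring untouched, so it gives no direct size for the next change. Compound 4 (`COc1ccc(-c2noc(CCCCCCC(=O)C(F)(F)F)n2)cc1`) differs from compound 3 by methoxy in place of hydrogen on an aromatic carbon (methoxy in place of hydrogen on an aromatic carbon, phenyl to 4-methoxyphenyl). Among the compounds with values here, no measured step isolates a substituent on that ring, so no step beyond the scatter is expected in this assay here. The expected change is a 1.2-fold lower number from compound 3 to compound 4 (0.07 log units; within the scatter) and is estimated to stay small. For compound 4 the estimate is 6500 nM with an expected range from 2500 nM to 17000 nM as the upper end.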

Compound 4, half-maximal inhibitory concentration: 35900 nM
Compound 4: middle estimate off by 5.5-fold (0.74 log units), on the low side; the whole stated range lies below it.
By their numbers in this assay, from the lowest: compounds 1 and 3 (each within the scatter of the next); then compounds 2 and 4 (each within the scatter of the next).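

In this assay, going by these compounds alone, a substituent on the aromatic ring is read directly for the first time: methoxy in place of hydrogen, para to a large group, gives a 4.7-fold higher number from compound 3 to compound 4 (0.67 log units; beyond the scatter). This position therefore does not tolerate every change, at least with the trifluoromethyl carbonyl end in place. No evidence on hand accounts for this step.

As far as these compounds go, whether the higher number is specific to methoxy remains open, since fluoro or an amine at this position could behave differently. From the compounds shown here alone, whether the step carries over to the hydroxamic acid or anilide ends also remains open.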